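The source may hold more compounds than are shown below. What is called first, only, known or untested is meant among the compounds shown, and "the series" means these compounds.

Measured so far:
compound 1 `CN1Cc2c(N)cccc2C(c2ccc(Cl)cc2)C1`, 1.5 mg/kg
compound 2 `CC(C)c1ccc(C2CN(C)Cc3c(N)cccc32)cc1`, about 65 mg/kg

Both compounds were tested in a functional assay on the whole organism for inhibition of sodium-dependent dopamine transporter (Mus musculus); a lower number here means that less compound is needed, a higher number that more compound is needed for the effect. Among the compounds with values here, compound 1 gives the lowest of the two numbers; the only other value belongs to compound 2, reached by the step of a 43-fold higher number from compound 1 to compound 2 (1.64 log units; beyond the scatter), which swaps the group on the aromatic ring that hangs from the shared core.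

Compound 3 `CCNCC(=O)Nc1cccc2c1CN(C)CC2c1ccc(Cl)cc1` has not been tested yet. It keeps everything of compound 1 and changes one spot: ((ethylamino)methyl)carbonyl in place of hydrogen on a nitrogen on an aromatic ring. Within the data shown here, the only measured step, from compound 1 to compound 2, concerns a different part of the molecule, so it says nothing direct about a change at the ring nitrogen. Among the measured compounds shown here, there is thus no precedent for this kind of step within this set, and the expectation must stay wide.

On that basis compound 3 is expected to give 3 mg/kg, within a range of 0.8 mg/kg to 15 mg/kg, so that the expected step is a 2.0-fold higher number from compound 1 to compound 3 (0.30 log units; within the scatter).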

Compound 3, dose for half-maximal effect: about 25 mg/kg
Compound 3: the middle estimate sits 8.3-fold (0.92 log units) below what was measured, outside the stated range (above it).
By their numbers in this assay, from the lowest: compound 1; then compound 3; then compound 2.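

Within the data shown here, until this result, the only change on record was on the aromatic ring that hangs from the shared core. In this assay, placing ((ethylamino)methyl)carbonyl on the nitrogen on an aromatic ring gives a 17-fold higher number from compound 1 to compound 3 (1.22 log units; beyond the scatter) and so shows that this second spot also responds strongly to a single change, here towards more compound being needed. No measurement at hand bears on why the number rises.

The compounds shown leave open whether a simple acetyl on this nitrogen would stay closer to compound 1 at 1.5 mg/kg or would also raise the number. They also leave open whether the ethylamino end of the chain matters, which a carboxylic acid or a longer chain in its place could test.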